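Trifluoromethyl Gives Way to Chloro on an Aromatic Carbon

The source may hold more compounds than are shown below. What is called first, only, known or untested is meant among the compounds shown, and "the series" means these compounds.

Of the compounds shown here, three with a shared core have been measured in a functional assay on HepG2 cells (Homo sapiens) for inhibition, read by MTT assay, with a stated time of 72 h; a lower number here means a stronger inhibitor, a higher number a weaker inhibitor. There, compound 1 `CCCc1ccc(NC(=O)C2CCN(C/C=C/c3ccccc3)CC2)cc1` gives 9410 nM, compound 2 `COc1ccc(NC(=O)C2CCN(C/C=C/c3ccccc3)CC2)cc1` gives 88800 nM and compound 3 `O=C(Nc1cccc(C(F)(F)F)c1)C1CCN(C/C=C/c2ccccc2)CC1` gives 11400 nM. Compound 3 therefore lies within the usual scatter of compound 1, and both sit clearly lower than compound 2, so they are the stronger inhibitors.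

The next compound, compound 4 `O=C(Nc1cccc(Cl)c1)C1CCN(C/C=C/c2ccccc2)CC1`, differs from compound 3 in one place: chloro in place of trifluoromethyl on an aromatic carbon. This puts chloro in place of trifluoromethyl on an aromatic carbon, meta to a large group. Among the measured compounds shown here, no measured step covers this exact swap. The closest evidence is a different one, methoxy in place of propyl on an aromatic carbon, a 9.4-fold higher number from compound 1 to compound 2 (0.97 log units; beyond the scatter). That single step shows that a change on an aromatic carbon can move the number, but it gives no direction for this one. The expected step is therefore none beyond the scatter, a 1.1-fold higher number from compound 3 to compound 4 (0.02 log units; within the scatter). In this assay, compound 4 is estimated at 12000 nM, with an expected range from 5000 nM to 30000 nM.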

Compound 4, half-maximal inhibitory concentration: 20000 nM
Compound 4: the middle estimate sits 1.7-fold (0.22 log units) below what was measured; the measured number falls inside the stated range.
By their numbers in this assay, from the lowest: compounds 1, 3 and 4 (each within the scatter of the next, the first and the last beyond it); then compound 2.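

In this assay, exchanging trifluoromethyl, with 4 heavy atoms, for chloro, with 1 heavy atom, on this aromatic carbon meta to a large group gives a 1.8-fold higher number from compound 3 to compound 4 (0.24 log units; within the scatter), so this smaller group keeps the number close to that of compound 3. Changes to the whole aromatic group on the amide-type nitrogen reach beyond the scatter in both directions: 3-chlorophenyl in place of 4-methoxyphenyl gives a 4.4-fold lower number from compound 2 to compound 4 (0.65 log units; beyond the scatter), and 3-chlorophenyl in place of 4-propylphenyl gives a 2.1-fold higher number from compound 1 to compound 4 (0.33 log units; beyond the scatter), though each of these steps changes both the group and its place on the ring. Nothing available explains why these numbers differ.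

The compounds shown leave open how an amine, a hydroxyl or a carboxylic acid on this same aromatic carbon would affect the number. They also leave open whether chloro and trifluoromethyl would again stay this close on a different aromatic carbon.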